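Chloro addition on the shared core of the cinnamonitrile series

A few compounds are considered here, and "the series" means these few. Any claim that something is new, unique, unknown or untested is made for them only; others in the source may bear on it.

Three measured compounds frame the question. Compound 1 `Cc1cc(C)c(Oc2nc(Cl)ncc2NCCn2ccc(=O)[nH]c2=O)c(C)c1` gives 2890 nM in an ADME assay on MT4 cells (Homo sapiens) for cytotoxicity, read by MTT assay, with a stated time of 5 days; on this read-out lower numbers stand for higher toxicity in this test and higher numbers for lower toxicity in this test. Compound 3 `Cc1cc(C)cc(Oc2ccnc(NCCn3ccc(=O)[nH]c3=O)n2)c1` gives 74800 nM in this assay. Compound 2 `Cc1cc(/C=C/C#N)cc(C)c1Oc1ccnc(NCCn2ccc(=O)[nH]c2=O)n1` reaches only the limit of this assay, recorded as > 309000 nM; this is a limit of the assay and not a number. Among the measured compounds shown here, compound 2 therefore stands at the least toxic end of the values shown, the one value that is a limit, as noted in the limit of > 309000 nM in this assay, at which 1 of the 3 values shown sits.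

Compound 4 `Cc1cc(/C=C/C#N)cc(C)c1Oc1cc(Cl)nc(NCCn2ccc(=O)[nH]c2=O)n1` differs from compound 2 by the change (chloro in place of hydrogen on an aromatic carbon). For the measured compounds named here, no measured pair differing in this single place exists among the three compounds, so the size of the step cannot be read from the data. The expectation is a modest step from compound 2 to compound 4 in this assay toward higher toxicity, of a size that may or may not exceed the scatter, giving an estimated at least 2.5-fold lower number from compound 2 to compound 4 (0.41 log units; beyond the scatter). Compound 4 is expected to give 120000 nM in this assay, within a range of 25000 nM to 400000 nM.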

Compound 4, half-maximal cytotoxic concentration: > 284000 nM
Compound 4 ended at the assay's limit; the forecaster's own chance of this, stated with the estimate: 40%; at least 2.3-fold (0.37 log units) between middle value and limit.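

In this assay, among the compounds shown here, compound 2 and compound 4 both end at a limit and not at a number, and no step for chloro in place of hydrogen can be read between them. The compounds shown leave open whether this chloro shifts the read-out at all, in either direction.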